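Removing tert-butyl from inactive compound 3

The source may report more compounds than this note shows. Statements on the series, on what has been measured and on what is new or still open speak of the compounds shown alone.

For the measured compounds named here, in a functional assay on MCF7 cells (Homo sapiens) for antiproliferative activity, with a stated time of 96 h (a lower number here means a stronger inhibitor, a higher number a weaker inhibitor), compound 1 `Cc1cc(=O)oc2cc(OCC(=O)c3ccc(C(C)(C)C)cc3)ccc12` gives 20700 nM and holds the only numerical reading so far. Compound 2 `Cc1cc(=O)oc2cc(OCC(=O)c3ccc4c(c3)OCCCO4)ccc12` is recorded at > 100000 nM in this assay, and this is a limit of the assay, not a number. Compound 3 `CC(C)(C)c1ccc(C(=O)COc2ccc3c(C(F)(F)F)cc(=O)oc3c2)cc1` is reported as "not active" (no number reported) in this assay and so has no number and no exact place on the scale.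

The next compound to read is compound 4 `O=C(COc1ccc2c(C(F)(F)F)cc(=O)oc2c1)c1ccccc1`, which has not yet been measured. The structural change puts hydrogen in place of tert-butyl on an aromatic carbon, para to a large group (hydrogen in place of tert-butyl on an aromatic carbon).

Without a number for compound 3, the size of this step cannot be read from the data. No gain beyond the scatter is expected in this assay, so weak activity should persist, and a report without a number remains quite possible. This expectation rests on compound 3 at "not active" (no number reported) as the direct reference point. In this assay the estimate for compound 4 is an expected 70000 nM with an estimated range of 25000 nM to 100000 nM for a numerical result.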

Compound 4, half-maximal inhibitory concentration: "not active" (no number reported)
Compound 4: no number reported; no gap can be computed for the estimate.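

Compound 3 and compound 4 are both reported as not active in this assay, with no number for either, so no step can be read for the exchange of tert-butyl for hydrogen. No evidence at hand bears on this result. The compounds shown leave open whether this exchange changes activity at all on a scale of numbers.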